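Replacing a nitrooxypropyl ester with an isopropyl ester

The compounds below may be only part of what the source reports. "The series", "measured", "known", "first", "only" and "open" are said of these compounds alone.

Measured so far:
compound 1, `CC1=C(C(=O)OCCCCO[N+](=O)[O-])C(c2cccc3nonc23)C([N+](=O)[O-])=C(C)C1`: 878 nM
compound 2, `CC1=C(C(=O)OCCCO[N+](=O)[O-])C(c2cccc3nonc23)C([N+](=O)[O-])=C(C)C1`: 241 nM

Of the compounds shown here, two sharing one core have been tested in a functional assay (ileum) for antagonist activity, with Cavia porcellus as the target; a higher number here means a weaker inhibitor, a lower number a stronger inhibitor. Compound 1 gives 878 nM, and compound 2 gives 241 nM, the lowest of the two numbers. The step of a 3.6-fold lower number from compound 1 to compound 2 (0.56 log units; beyond the scatter) shows that shortening the ester chain moved the number down. Compound 3, `CC1=C(C(=O)OC(C)C)C(c2cccc3nonc23)C([N+](=O)[O-])=C(C)C1`, is not yet measured; its change from compound 2 is isopropyl in place of 3-(nitrooxy)propyl on an oxygen next to a carbonyl group. Among the measured compounds shown here, only the step from compound 1 to compound 2 bears on this, and only loosely, since it shortens the chain while the new change removes the nitrooxy group altogether. A further modest fall, or no change beyond the scatter, seems the likeliest outcome, but the evidence is thin. Compound 3 is therefore expected at about 180 nM, between 45 nM and 720 nM, a step of a 1.3-fold lower number from compound 2 to compound 3 (0.13 log units; within the scatter).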

Compound 3, half-maximal inhibitory concentration: 40 nM
For compound 3 the middle estimate is 4.5-fold (0.65 log units) above the measured one; measured number outside the range, below it.
By their numbers in this assay, from the lowest: compound 3; then compound 2; then compound 1.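

In this assay, isopropyl in place of 3-(nitrooxy)propyl on the oxygen next to the carbonyl group gives a 6.0-fold lower number from compound 2 to compound 3 (0.78 log units; beyond the scatter) and so shows that the number at this position can fall with no nitrooxy group on the chain at all. Measured against the longer 4-(nitrooxy)butyl, the same kind of exchange gives a 22-fold lower number from compound 1 to compound 3 (1.34 log units; beyond the scatter) and is the largest step among these three compounds. Nothing measured here accounts for either step.

From the compounds shown here alone, compound 3 loses the nitrooxy group, shortens the chain and adds a branch in one change, so the share of each remains unknown. A plain unbranched propyl chain would separate these effects, while a methyl or tert-butyl group would show how far the trend at this oxygen extends.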